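From 4-methylphenyl to 4-acetamidophenyl on the sulfonyl nitrogen

The source may report more compounds than this note shows. Statements on the series, on what has been measured and on what is new or still open speak of the compounds shown alone.

Values measured in a functional assay on SMMC-7721 cells (Homo sapiens) for cytotoxicity, read by MTT assay, with a stated time of 24 h (a lower number here means a stronger inhibitor, a higher number a weaker inhibitor), are as follows.

- Compound 1 `COc1ccc(/C=C2\CN(C)C/C(=C\c3ccncc3)C2=O)c(OC)c1OC` gives 9080 nM
- Compound 2 `O=C1/C(=C/c2cccnc2)CNC/C1=C\c1ccccc1F` gives > 20000 nM (a limit of the assay, not a number)
- Compound 3 `Cc1ccc(S(=O)(=O)N2C/C(=C\c3cccnc3)C(=O)/C(=C/c3ccccc3F)C2)cc1` gives 10300 nM

In this assay compound 3 gives 10300 nM and compound 1 gives 9080 nM so the two lie within the usual scatter of each other. The value of compound 2 is a limit of the assay, the limit of > 20000 nM in this assay, at which 1 of the 3 values shown sits, and not a number. Within the data shown here, the one measured step is an at least 1.9-fold lower number from compound 2 to compound 3 (0.28 log units; that floor lies within the scatter) and it puts (4-methylphenyl)sulfonyl in place of hydrogen on an amine nitrogen in a ring.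

Compound 4 `CC(=O)Nc1ccc(S(=O)(=O)N2C/C(=C\c3cccnc3)C(=O)/C(=C/c3ccccc3F)C2)cc1` differs from compound 3 elsewhere, with acetamido in place of methyl on an aromatic carbon, para to a large group (acetamido in place of methyl on an aromatic carbon). Among the measured compounds shown here, no measured step changes this group, so the one step available sets no size for it. The expectation therefore rests on compound 3 at 10300 nM with no shift beyond the scatter expected in either direction. The estimated step is a 1.1-fold lower number from compound 3 to compound 4 (0.04 log units; within the scatter) and it is expected to stay within the scatter. The expected value for compound 4 is 9500 nM (estimated range 3500 nM to 20000 nM).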

Compound 4, half-maximal inhibitory concentration: 10900 nM
Compound 4: middle estimate off by 1.1-fold (0.06 log units), on the low side; the range from low to high includes it.
By their numbers in this assay, from the lowest: compounds 1, 3 and 4 (each within the scatter of the next). At a limit, above all of these: compound 2.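

In this assay, acetamido in place of methyl on an aromatic carbon, para to a large group, gives a 1.1-fold higher number from compound 3 to compound 4 (0.02 log units; within the scatter) and so leaves the number within the scatter, even though the new group brings more heavy atoms and a hydrogen-bond donor and acceptor that methyl lacks. Among these compounds, the earlier step concerned only the ring nitrogen, where (4-methylphenyl)sulfonyl replaced hydrogen, and no earlier pair varied the group on the aromatic ring of that sulfonyl, so this is the first reading at this position. The data shown offer no measured property that bears on this result.

Among the compounds shown here, whether a carboxylic acid, an amine or a longer chain at the same place would also stay within the scatter remains open, since methyl and acetamido are the only two groups compared there. Going by these compounds, it also remains open whether the same change would behave alike with the other groups on the shared core, as this single pair of compounds holds the 2-fluorophenyl and 3-pyridyl parts fixed.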